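The source may report more compounds than this note shows. Statements on the series, on what has been measured and on what is new or still open speak of the compounds shown alone.

Compound 1, `COCCn1c(SCc2cc([N+](=O)[O-])ccc2OC)nc2cc(NC(=O)NC(C)(C)C)ccc21`: 57 nM
Compound 2, `COc1ccc([N+](=O)[O-])cc1CSc1nc2cc(NC(=O)NC(C)(C)C)ccc2n1Cc1ccccn1`: 43 nM

In an assay on isolated protein for inhibition of Gonadotropin-releasing hormone receptor (Homo sapiens) (a higher number here means a weaker inhibitor, a lower number a stronger inhibitor), compound 2 gives 43 nM, while compound 1 gives 57 nM; the step of a 1.3-fold lower number from compound 1 to compound 2 (0.12 log units; within the scatter) does not separate the two. Compound 3, `COc1ccc([N+](=O)[O-])cc1CSc1nc2cc(NC(=O)NC(C)(C)C)ccc2n1-c1ccccc1`, differs from compound 2 by phenyl in place of (pyridin-2-yl)methyl on an aromatic nitrogen. Within the data shown here, the only measured step at this position, a 1.3-fold lower number from compound 1 to compound 2 (0.12 log units; within the scatter), exchanged a group on a saturated chain carbon bound to the aromatic nitrogen and stayed within the scatter; no measured step removes that chain carbon. The shift is therefore expected to be small, with compound 3 estimated at 70 nM, between 25 nM and 250 nM, a step of a 1.6-fold higher number from compound 2 to compound 3 (0.21 log units; within the scatter).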

Compound 3, half-maximal inhibitory concentration: 350 nM
For compound 3 the middle estimate is 5.0-fold (0.70 log units) below the measured one; the measured number lies above the stated range.
By their numbers in this assay, from the lowest: compounds 2 and 1 (each within the scatter of the next); then compound 3.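

In this assay the group on the aromatic nitrogen proves to matter: phenyl in place of (pyridin-2-yl)methyl gives an 8.1-fold higher number from compound 2 to compound 3 (0.91 log units; beyond the scatter) and phenyl in place of 2-methoxyethyl gives a 6.1-fold higher number from compound 1 to compound 3 (0.79 log units; beyond the scatter). Unlike the earlier exchange on the chain carbon, both steps lie beyond the scatter, and both remove the saturated chain carbon so that a ring sits directly on the nitrogen. Going by these compounds, what a benzyl group, with its chain carbon and a ring of carbon only, or a pyridin-2-yl ring bound directly to the nitrogen would give stays open. Nothing shown gives a reason for this loss.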